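One Side Group Exchanged: From Compound 1 to Compound 4

A few compounds are considered here, and "the series" means these few. Any claim that something is new, unique, unknown or untested is made for them only; others in the source may bear on it.

Measured so far, in an assay on CHO cells for displacement of a labelled ligand from 5-hydroxytryptamine receptor 1D (Homo sapiens); a higher number here means a weaker inhibitor, a lower number a stronger inhibitor:
Compound 1 `O=S(=O)(NCC1CCN(CCCc2c[nH]c3ccc(-n4cnnc4)cc23)CC1)c1ccccc1` gives 6.2 nM.
Compound 2 `O[C@H]1Cc2ccccc2C1NC1CCN(CCCc2c[nH]c3ccc(-n4cnnc4)cc23)CC1` gives 37 nM.
Compound 3 `CC(C)=CCCN(C)C1CCN(CCCc2c[nH]c3ccc(-n4cnnc4)cc23)CC1` gives 2.6 nM.

Compound 1 stands second highest of these three numbers: the step of a 2.4-fold lower number from compound 1 to compound 3 (0.38 log units; beyond the scatter) places compound 3 below it, and the step of a 6.0-fold higher number from compound 1 to compound 2 (0.78 log units; beyond the scatter) places compound 2 above it, both beyond the scatter.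

Compound 4 `O[C@@H]1Cc2ccccc2[C@H]1NC1CCN(CCCc2c[nH]c3ccc(-n4cnnc4)cc23)CC1` is not yet measured. Its change from compound 1 is (2-hydroxy-2,3-dihydro-1H-inden-1-yl)amino in place of ((phenylsulfonyl)amino)methyl on a saturated ring carbon. The step of a 6.0-fold higher number from compound 1 to compound 2 (0.78 log units; beyond the scatter) bears directly on this, since compound 2 carries the same entering group and differs from compound 4 only in which stereocentres are defined. A step of similar size and direction, towards a weaker binder, is therefore expected: a 4.8-fold higher number from compound 1 to compound 4 (0.68 log units; beyond the scatter). Compound 4 is estimated at 30 nM, with a range from 10 nM to 100 nM.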

Compound 4, half-maximal inhibitory concentration: 6.6 nM
Compound 4: middle estimate off by 4.5-fold (0.66 log units), on the high side; the measured number lies below the stated range.
By their numbers in this assay, from the lowest: compound 3; then compounds 1 and 4 (each within the scatter of the next); then compound 2.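

In this assay, exchanging the group on this saturated ring carbon gives a 1.1-fold higher number from compound 1 to compound 4 (0.03 log units; within the scatter), so (2-hydroxy-2,3-dihydro-1H-inden-1-yl)amino is not in itself a penalty here, although a 2.5-fold higher number from compound 3 to compound 4 (0.40 log units; beyond the scatter). With the same atoms and bonds, the result still shifts with how the stereocentres are drawn, giving a 5.6-fold lower number from compound 2 to compound 4 (0.75 log units; beyond the scatter). This gap rests on one specific difference: the fact that one of compounds 2 and 4 is drawn with a defined configuration and the other without, at the place where they differ

From the compounds shown here alone, it remains open how the other fully drawn stereoisomers of this group would compare. Going by these compounds, it is also open whether a plain benzylamino group would fare as well on this ring carbon.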